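Compound 4: removing the dimethoxy pattern

The source may report more compounds than this note shows. Statements on the series, on what has been measured and on what is new or still open speak of the compounds shown alone.

Values so far in a functional assay on THP-1 cells (Homo sapiens) for inhibition, read by sulforhodamine B assay, with a stated time of 48 h, tested at 50 uM (on this read-out lower numbers stand for less inhibition of growth and higher numbers for more inhibition of growth at the one concentration tested), are these:
compound 1 `COc1ccc(/C=C/C(=O)/C=C/c2ccc(OCc3cn(CCCCOc4cc(=O)oc5ccccc45)nn3)c(OC)c2)cc1OC` gives 59%
compound 2 `COc1ccc(/C=C/C(=O)/C=C/c2ccc(OCc3cn(CCCCCOc4cc(=O)oc5ccccc45)nn3)c(OC)c2)cc1OC` gives 47%
compound 3 `COc1ccccc1/C=C/C(=O)/C=C/c1ccc(OCc2cn(CCCOc3cc(=O)oc4ccccc34)nn2)c(OC)c1` gives 50%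

Compound 1 lies within the scatter of compound 3 and beyond the scatter above compound 2. The move to compound 4 `COc1cc(/C=C/C(=O)/C=C/c2ccccc2)ccc1OCc1cn(CCCCOc2cc(=O)oc3ccccc23)nn1` is phenyl in place of 3,4-dimethoxyphenyl on a double-bonded chain carbon bound to a double-bonded chain carbon and is the only difference between the two structures. Among the compounds with values here, no two measured compounds differ in one place only, so the data offer no direct size for this change. In this assay a modest fall is expected, not beyond the scatter. Estimated here is a number 9 percentage points lower from compound 1 to compound 4 (within the scatter) as the likeliest outcome. That expectation rests on compound 2 at 47% and compound 1 at 59% as the edges of a narrow measured spread. For compound 4 the estimated value is 50% with an expected range from 35% to 65% as the working figure.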

Compound 4, percent growth inhibition at one concentration: 36%
The estimate for compound 4 lay 14 percentage points above the measured number; low and high end bracket the measured number.
By their numbers in this assay, from the lowest: compound 4; then compounds 2, 3 and 1 (each within the scatter of the next, the first and the last beyond it).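

In this assay, within the data shown here, phenyl in place of 3,4-dimethoxyphenyl on a double-bonded chain carbon bound to a double-bonded chain carbon gives a number 23 percentage points lower from compound 1 to compound 4 (beyond the scatter) and is the first single-place comparison. This position is therefore not indifferent to the change, and growth inhibition falls when the two methoxy groups leave. Nothing available explains the fall.

Going by these compounds, whether one methoxy group would suffice remains open, as does the effect of a hydroxyl or an amine on that ring. Whether the same fall holds with the shorter or longer chains of the series is also unknown.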